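A few compounds are considered here, and "the series" means these few. Any claim that something is new, unique, unknown or untested is made for them only; others in the source may bear on it.

Within the data shown here, in a functional assay on EC9706 cells (Homo sapiens) for antiproliferative activity, read by MTT assay, with a stated time of 72 h (on this read-out lower numbers stand for stronger inhibition and higher numbers for weaker inhibition), compound 2 `CN(C)C(=S)SCC1=CCOC1=O` gives 182000 nM, the highest of the three numbers measured so far. Compound 1 `O=C1OCC=C1CSC(=S)NC1CC1` gives 53600 nM, and compound 3 `O=C1CC2(CO1)CSC(=S)N2c1ccc(Cl)cc1` gives 32600 nM. Compound 4 `O=C1OCC=C1CSC(=S)N1CCCC1` has not yet been measured; it differs from compound 2 by pyrrolidin-1-yl in place of dimethylamino on a thiocarbonyl carbon. Among the measured compounds shown here, the only measured step at this place is a 3.4-fold higher number from compound 1 to compound 2 (0.53 log units; beyond the scatter), where dimethylamino replaced cyclopropylamino on the thiocarbonyl carbon and the number rose. Swapping dimethylamino for pyrrolidin-1-yl at the same place is a change of comparable size, so a modest step in this assay is expected, most likely downward, in the order of a 2.0-fold lower number from compound 2 to compound 4 (0.31 log units; beyond the scatter). Compound 4 is therefore estimated at 90000 nM, within a range from 30000 nM to 250000 nM.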

Compound 4, half-maximal inhibitory concentration: 14400 nM
Beside the measured number, compound 4's estimate is 6.3-fold (0.80 log units) above it; measured number outside the range, below it.
By their numbers in this assay, from the lowest: compound 4; then compounds 3 and 1 (each within the scatter of the next); then compound 2.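

At this place on the thiocarbonyl carbon, the choice of amine can matter far more than the first step suggested: pyrrolidin-1-yl in place of dimethylamino gives a 13-fold lower number from compound 2 to compound 4 (1.10 log units; beyond the scatter), a large change for two added carbons. Pyrrolidin-1-yl in place of cyclopropylamino gives a 3.7-fold lower number from compound 1 to compound 4 (0.57 log units; beyond the scatter), so of the three groups tried here, pyrrolidin-1-yl gives the lowest number. No measurement at hand speaks to what lies behind these steps. Still open, as far as these compounds go, is whether piperidin-1-yl, morpholin-4-yl or diethylamino would push the number lower or raise it.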